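The compounds below may be only part of what the source reports. "The series", "measured", "known", "first", "only" and "open" are said of these compounds alone.

In an ADME assay on HCT-116 cells (Homo sapiens) for cytotoxicity, read by CellTiter-Glo, with a stated time of 72 h (a lower number here means a stronger inhibitor, a higher number a weaker inhibitor), compound 1 `COc1ccccc1-c1cccc(S(=O)(=O)N2CCC(N3CCC(C)CC3)CC2)c1` returns only a limit, > 5000 nM. Compound 2 `Cc1cc(C)c(S(=O)(=O)N2CCC(N3CCN(C)CC3)CC2)c(C)c1` also reaches only a limit in this assay, > 5000 nM. Compound 3 `Cc1cc(C)c(S(=O)(=O)NC2CCN(C3CCN(C)CC3)CC2)c(C)c1` likewise gives a limit, > 5000 nM. Compound 1 thus stands at the limit of > 5000 nM in this assay, at which 3 of the 3 values shown sit, with no number to set it apart from the others. Compound 4 `CC1CCN(C2CCN(S(=O)(=O)c3cccc(Br)c3)CC2)CC1` has not yet been tested in this assay; it differs from compound 1 by bromo in place of 2-methoxyphenyl on an aromatic carbon. Going by the values given here, no step between measured compounds bears on this change, so in this assay the move to compound 4 is expected to amount to none beyond the scatter, with the result most probably remaining a limit. Compound 4 is estimated at 8000 nM, within 3000 nM to 30000 nM. The expected step is a step that the limit leaves unreadable from compound 1 to compound 4.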

Compound 4, half-maximal inhibitory concentration: > 5000 nM
Compound 4: a limit, no number; the forecaster's own chance of this, stated with the estimate: 85%; the middle value does not contradict the limit.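

In this assay compound 4 also gives only a limit, > 5000 nM. Going by these compounds alone, compound 1 is a limit too, and no step from compound 1 to compound 4 can be read. The compounds shown leave open whether any of them differs from another in this assay: the limit of > 5000 nM in this assay, at which 4 of the 4 values shown sit.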